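Swapping one aryl group on the shared core

The compounds below may be only part of what the source reports. "The series", "measured", "known", "first", "only" and "open" are said of these compounds alone.

Of the compounds shown here, three built on the same core have been tested in a functional assay on cells (Cancer cell lines, Homo sapiens) for cytotoxicity, read by sulforhodamine B assay, with a stated time of 48 h; on this read-out lower numbers stand for stronger inhibition of growth and higher numbers for weaker inhibition of growth. Compound 1 `COc1ccc(C2CC(c3ccccc3)=NN2C2=NC(=O)/C(=C3\C(=O)Nc4ccccc43)S2)cc1` gives 2300 nM. Compound 2 `COc1ccc(C2=NN(C3=NC(=O)/C(=C4\C(=O)Nc5ccccc54)S3)C(c3ccc(OC)cc3)C2)cc1` gives 92200 nM, the highest number of the three and so the weakest growth inhibitor among them. Compound 3 `COc1ccc(C2=NN(C3=NC(=O)/C(=C4\C(=O)Nc5ccc(Cl)cc54)S3)C(c3ccc(OC)cc3)C2)cc1` gives 230 nM. Two single changes link these numbers: a 40-fold higher number from compound 1 to compound 2 (1.60 log units; beyond the scatter), and a 400-fold lower number from compound 2 to compound 3 (2.60 log units; beyond the scatter). Compound 4 `COc1ccc(C2CC(c3ccc4ccccc4c3)=NN2C2=NC(=O)/C(=C3\C(=O)Nc4ccccc43)S2)cc1` has not yet been measured; it differs from compound 2 in that (naphthalen-2-yl in place of 4-methoxyphenyl on a carbon with a double bond to nitrogen). For the measured compounds named here, of the measured steps, only the step from compound 1 to compound 2 concerns the same place on the core, and there a methoxy group added to that aryl ring pushed the number far upward. Compound 4 removes that methoxy group and replaces the ring with a larger one, so a return toward the number of compound 1 seems the most likely outcome, with the larger ring adding uncertainty. Compound 4 is therefore expected to give about 3000 nM, within 400 nM to 25000 nM, an estimated 31-fold lower number from compound 2 to compound 4 (1.49 log units; beyond the scatter).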

Compound 4, concentration for 50% growth inhibition: 970 nM
Beside the measured number, compound 4's estimate is 3.1-fold (0.49 log units) above it, within the range that was stated.
By their numbers in this assay, from the lowest: compound 3; then compound 4; then compound 1; then compound 2.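

For the compounds shown here, at this position the earlier compounds showed only that 4-methoxyphenyl gave a far higher number than phenyl, and the new result shows that a larger aryl group need not do the same. Replacing 4-methoxyphenyl with naphthalen-2-yl brings a large drop (a 95-fold lower number from compound 2 to compound 4 (1.98 log units; beyond the scatter)), and naphthalen-2-yl also edges past phenyl in a modest step (a 2.4-fold lower number from compound 1 to compound 4 (0.37 log units; beyond the scatter)). Among these three groups, then, the number does not rise with heavy-atom count: naphthalen-2-yl has the most heavy atoms and gives the lowest number. Nothing available explains why these groups differ.

From the compounds shown here alone, it remains open how a ring bearing an amine or a carboxylic acid would behave at this position. Also unknown is whether the chloro group that lowered the number in compound 3 would do so alongside naphthalen-2-yl.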